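Spiro series: amide terminus swap on compound 2

A few compounds are considered here, and "the series" means these few. Any claim that something is new, unique, unknown or untested is made for them only; others in the source may bear on it.

Measured in an assay on HEK293 cells for displacement of a labelled ligand from NPC1-like intracellular cholesterol transporter 1 (Homo sapiens); on this read-out higher numbers stand for weaker inhibition and lower numbers for stronger inhibition:
compound 1 `O=C(CN1CN(c2ccccc2)C2(CCN(C(=O)c3ccc(C4CCCCC4)cc3)CC2)C1=O)NCCCCO` gives 10300 nM
compound 2 `CC(C)(C)c1ccc(C(=O)N2CCC3(CC2)C(=O)N(CC(=O)NCCN)CN3c2ccccc2)cc1` gives 7000 nM
compound 3 `NCCNC(=O)CN1CN(c2ccccc2)C2(CCN(C(=O)c3ccc(C4CCCCC4)cc3)CC2)C1=O` gives 3800 nM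

On these three numbers compound 2 sits between the other two, within the scatter of both: compound 1 gives a number that differs from it only within the scatter, and the step of a 1.8-fold lower number from compound 2 to compound 3 (0.27 log units; within the scatter) is likewise within the scatter. Among the compounds with values here, the only step beyond the scatter is a 2.7-fold lower number from compound 1 to compound 3 (0.43 log units; beyond the scatter).

Compound 4 `CC(C)(C)c1ccc(C(=O)N2CCC3(CC2)C(=O)N(CC(=O)N2CCCCC2CCO)CN3c2ccccc2)cc1` differs from compound 2 in one place: 2-(2-hydroxyethyl)piperidin-1-yl in place of (2-aminoethyl)amino on a carbonyl carbon. Within the data shown here, no measured step covers this exact change. The step of a 2.7-fold lower number from compound 1 to compound 3 (0.43 log units; beyond the scatter) is the nearest guide, since it replaces a 2-hydroxyethyl terminus by an amino terminus and the present change runs the other way, from an amine-bearing terminus to a hydroxyethyl-bearing one, while also replacing the amide hydrogen by a ring. On that basis a modest move towards weaker inhibition is expected in this assay, of about a 2.3-fold higher number from compound 2 to compound 4 (0.36 log units; beyond the scatter). Compound 4 is therefore estimated at 16000 nM, with a range from 5000 nM to 45000 nM.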

Compound 4, half-maximal inhibitory concentration: 6100 nM
For compound 4 the middle estimate is 2.6-fold (0.42 log units) above the measured one, and the stated range covers the measured number.
By their numbers in this assay, from the lowest: compounds 3, 4, 2 and 1 (each within the scatter of the next, the first and the last beyond it).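

On the carbonyl carbon of the side chain, 2-(2-hydroxyethyl)piperidin-1-yl, with 9 heavy atoms and a six-membered ring, stands in place of the 4 heavy atoms of (2-aminoethyl)amino with no separation beyond the scatter in this assay (a 1.1-fold lower number from compound 2 to compound 4 (0.06 log units; within the scatter)). In this tert-butyl pair, a terminus without the amino group and without the amide hydrogen therefore reads the same as the aminoethyl one, whereas the cyclohexyl pair, with a different change at the same carbonyl carbon, shows a step beyond the scatter (a 2.7-fold lower number from compound 1 to compound 3 (0.43 log units; beyond the scatter)). No available evidence accounts for this reading.

Still open, going by these compounds, is whether 2-(2-hydroxyethyl)piperidin-1-yl gives a similar reading with cyclohexyl in place of tert-butyl. Also open, on these data alone, is how unsubstituted piperidin-1-yl, or a carboxylic acid on a longer chain, would read at this carbonyl carbon.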